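Aminothiophene piperazines: arylpiperazine to pyridinylpiperazine

A few compounds are considered here, and "the series" means these few. Any claim that something is new, unique, unknown or untested is made for them only; others in the source may bear on it.

Compound 1 `Nc1scc(CN2CCN(c3cc(Cl)cc(Cl)c3)CC2)c1C(=O)c1ccc(Cl)cc1`: -1%
Compound 2 `Nc1scc(CN2CCN(c3ccc(F)cc3Cl)CC2)c1C(=O)c1ccc(Cl)cc1`: 6.1%

Among the measured compounds shown here, in a functional assay on CHO cells with adenosine receptor A1 (Homo sapiens) as the target, read by cAMP accumulation and immunoassay, with a stated time of 6 min, tested at 0.01 uM (a lower number here means a stronger effect, a higher number a weaker effect of the compound at the concentration tested), compound 2 gives 6.1%, the higher of the two numbers, while compound 1 gives -1%; the single measured step, a number 7.1 percentage points higher from compound 1 to compound 2 (within the scatter), lies within the scatter. Compound 3 `Nc1scc(CN2CCN(c3ccncc3)CC2)c1C(=O)c1ccc(Cl)cc1` differs from compound 2 in one place: pyridin-4-yl in place of 2-chloro-4-fluorophenyl on an amine nitrogen in a ring. For the measured compounds named here, no measured step involves a pyridin-4-yl group, so only the two near-zero readings guide the expectation. Compound 3 is therefore expected to give 3%, within -10% to 16%. This estimate means an expected step of a number 3.1 percentage points lower from compound 2 to compound 3 (within the scatter), no change beyond the scatter.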

Compound 3, a percentage reported as activity, at one concentration (the size of the read-out at that concentration, not a potency): -4%
Beside the measured number, compound 3's estimate is 7 percentage points above it; measured number inside the range.
By their numbers in this assay, from the lowest: compounds 3, 1 and 2 (each within the scatter of the next, the first and the last beyond it).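

Among the compounds shown here, on an amine nitrogen in a ring, pyridin-4-yl is the first group here with a ring hetero atom and a hydrogen-bond acceptor, and in this assay it gives the first step beyond the scatter, a number 10.1 percentage points lower from compound 2 to compound 3 (beyond the scatter). Against the other halogenated phenyl, the same replacement gives a number 3 percentage points lower from compound 1 to compound 3 (within the scatter), so the outcome depends on which group leaves. Nothing available explains the difference.

From the compounds shown here alone, whether a pyridin-3-yl or pyridin-2-yl group would read like pyridin-4-yl remains open. So does the reading with an unsubstituted phenyl group.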